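Swapping 3-bromopropyl for acetyl on the shared core

The compounds below may be only part of what the source reports. "The series", "measured", "known", "first", "only" and "open" are said of these compounds alone.

Among the compounds with values here, compound 1 (`BrCCCOc1c(Br)cc(Br)cc1Oc1ccc(Br)cc1Br`) and compound 2 (`Brc1ccc(Oc2cc(Br)cc(Br)c2OCCCCCN2CCN(c3ccccc3)CC2)c(Br)c1`) are the only two compounds with numbers so far. In a functional assay on U-937 cells (Homo sapiens) for cytotoxicity, read by MTT assay, with a stated time of 24 h (on this read-out higher numbers stand for weaker inhibition and lower numbers for stronger inhibition), compound 1 gives 30.3 ug/mL and compound 2 gives 42.5 ug/mL. Within the data shown here, these two values lie within the scatter of each other, so compound 1 stands level with the only other measured compound and no ranking can be drawn.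

The next compound is compound 3 (`CC(=O)Oc1c(Br)cc(Br)cc1Oc1ccc(Br)cc1Br`), which places acetyl in place of 3-bromopropyl on an oxygen on an aromatic ring. Among the measured compounds shown here, no step between measured compounds that differ in one place is available, so nothing measured shows what this change does, and the expectation is only a weak one. It rests on compound 1 at 30.3 ug/mL as the starting point. In this assay, no step beyond the scatter is expected, in either direction, and the estimate amounts to a 1.2-fold lower number from compound 1 to compound 3 (0.07 log units; within the scatter). The range is kept wide for that reason. For compound 3 the estimated value is 26 ug/mL, with an expected range from 10 ug/mL to 60 ug/mL.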

Compound 3, half-maximal inhibitory concentration: 32.3 ug/mL
Compound 3: middle estimate off by 1.2-fold (0.09 log units), on the low side, within the range that was stated.
By their numbers in this assay, from the lowest: compounds 1, 3 and 2 (each within the scatter of the next).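

In this assay, within the data shown here, this is the first comparison between compounds that differ in one place, and the step reads a 1.1-fold higher number from compound 1 to compound 3 (0.03 log units; within the scatter), which lies within the scatter. At an oxygen on an aromatic ring, therefore, acetyl in place of 3-bromopropyl gives no readable difference, even though the exchange removes the bromine-bearing chain and brings in a double bond outside aromatic rings and a hydrogen-bond acceptor. Among these compounds, this single step covers only the one exchange on the shared core, and no measurement of any other property bears on the result.

As far as these compounds go, whether a free hydroxyl, a longer acyl chain or a chain ending in a carboxylic acid on this oxygen would give a step beyond the scatter remains open. Compound 2 still has no partner among the compounds shown that differs from it in one place, so its value cannot yet be tied to any single change.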